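Swapping the pendant phenyl substituent: nitro out, methoxy in

A few compounds are considered here, and "the series" means these few. Any claim that something is new, unique, unknown or untested is made for them only; others in the source may bear on it.

Measured so far in a functional assay on HepG2 cells (Homo sapiens) for cytotoxicity, read by MTT assay, with a stated time of 72 h; on this read-out higher numbers stand for weaker inhibition and lower numbers for stronger inhibition:
compound 1 `COc1ccc(-c2cc(=O)c3c(O)cc(OCCCCN4CCN(C)CC4)c(OC)c3o2)cc1` gives 4200 nM
compound 2 `COc1c(OCCCCN2CCN(C)CC2)cc(O)c2c(=O)cc(-c3ccc(C)cc3)oc12` gives 1000 nM
compound 3 `COc1c(OCCCCN2CCN(C)CC2)cc(O)c2c(=O)cc(-c3ccc([N+](=O)[O-])cc3)oc12` gives 2620 nM

Compound 3 stands second highest of the three numbers in this assay: its value sits close to that of compound 1, the two being within the scatter of each other, while compound 2 sits clearly lower, as shown by a 2.6-fold higher number from compound 2 to compound 3 (0.42 log units; beyond the scatter). The new compound, compound 4 `COc1ccccc1-c1cc(=O)c2c(O)cc(OCCCCN3CCN(C)CC3)c(OC)c2o1`, differs from compound 3 in one place: 2-methoxyphenyl in place of 4-nitrophenyl on an aromatic carbon. Within the data shown here, two measured steps bear on this change. The step of a 1.6-fold lower number from compound 1 to compound 3 (0.20 log units; within the scatter) shows that exchanging a methoxy for a nitro group on this aromatic carbon changed little, whereas a 4.2-fold lower number from compound 1 to compound 2 (0.62 log units; beyond the scatter) shows that a methyl in place of the methoxy gave a modest drop. Among the measured compounds shown here, compound 4 returns a methoxy group to the ring, though on a different carbon than in compound 1; no measured pair tells how that relocation matters. A step near the scatter is therefore expected, a 1.3-fold higher number from compound 3 to compound 4 (0.13 log units; within the scatter), leaning slightly upward toward compound 1. Compound 4 is estimated at 3500 nM, within a range from 1500 nM to 8000 nM.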

Compound 4, half-maximal inhibitory concentration: 2330 nM
For compound 4 the middle estimate is 1.5-fold (0.18 log units) above the measured one; measured number inside the range.
By their numbers in this assay, from the lowest: compound 2; then compounds 4, 3 and 1 (each within the scatter of the next).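

In this assay, the step of a 1.8-fold lower number from compound 1 to compound 4 (0.26 log units; within the scatter) lies within the scatter, so shifting the methoxy group from 4-methoxyphenyl to 2-methoxyphenyl shows no measurable effect at this aromatic carbon next to the ring oxygen. Among these compounds, the step of a 1.1-fold lower number from compound 3 to compound 4 (0.05 log units; within the scatter) also lies within the scatter, which means that 2-methoxyphenyl and 4-nitrophenyl cannot be told apart here, while a 2.3-fold higher number from compound 2 to compound 4 (0.37 log units; beyond the scatter) is a modest step beyond the scatter and leaves the 4-methylphenyl of compound 2 as the only group of the four set apart. No measurement shown here offers a reason for this separation.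

On these data alone, how 2-methylphenyl would compare with the 4-methylphenyl of compound 2 remains open, so it is unclear whether the place of a methyl group on this ring matters. As far as these compounds go, it is also open whether plain phenyl, or a phenyl ring carrying an amine or a carboxylic acid, would read like compound 2 or like the other three.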